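Three Compounds at the Assay Limit and a Fourth

The source may report more compounds than this note shows. Statements on the series, on what has been measured and on what is new or still open speak of the compounds shown alone.

Compound 1 `O=c1cc(CSc2nc3ccccc3s2)oc2ccc(Cl)cc12`: > 25000 nM
Compound 2 `Cc1ccc2oc(CSc3nc4nc(C)cc(C)n4n3)cc(=O)c2c1`: > 25000 nM
Compound 3 `Cc1cc(C)n2nc(SCc3cc(=O)c4cc(Cl)ccc4o3)nc2n1`: > 25000 nM

In a functional assay on MDA-MB-435S cells (Homo sapiens) for cytotoxicity, read by MTT assay, with a stated time of 72 h (on this read-out higher numbers stand for weaker inhibition and lower numbers for stronger inhibition), compound 1 gives only a limit of the assay, > 25000 nM. In this assay compound 2 likewise gives a limit, > 25000 nM. In this assay compound 3 also gives a limit, > 25000 nM. The three values therefore share one position: the limit of > 25000 nM in this assay, at which 3 of the 3 values shown sit.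

Compound 3 and compound 2 differ in one place, (methyl in place of chloro on an aromatic carbon). The resulting step, a step that the two limits leave unreadable from compound 3 to compound 2, cannot be sized because both ends are limits. How the core of compound 1 differs from that of compound 3 is not broken down here.

Compound 4 `Cc1ccc2oc(CSc3nc4ccccc4s3)cc(=O)c2c1` differs from compound 1 by methyl in place of chloro on an aromatic carbon, the same change at a place described in the same words. Because the measured step that the two limits leave unreadable from compound 3 to compound 2 is unreadable, no direction is known for it. The step from compound 1 to compound 4 is expected to be a step that the limit leaves unreadable from compound 1 to compound 4, resting on the limit for compound 1, > 25000 nM. Compound 4 is estimated at 35000 nM, between 12000 nM and 120000 nM.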

Compound 4, half-maximal inhibitory concentration: > 25000 nM
Compound 4: only a limit was reported; the forecaster's own chance of this, stated with the estimate: 85%; the middle value lies beyond the limit too.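

In this assay compound 4 gives only a limit, > 25000 nM. Compound 1 also stands at a limit, so no step can be read between compound 1 and compound 4. The compounds shown therefore share one position: the limit of > 25000 nM in this assay, at which 4 of the 4 values shown sit.

They leave open how the four compounds rank against one another in this assay, and whether methyl in place of chloro on an aromatic carbon changes their activity at all.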